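Working notes: hydroxyphenyl regioisomer of compound 3

This account rests on a few compounds, and the source may have more. Where it says the series, first, only, none or still open, it means among the compounds named here.

Compound 1 `Oc1ccc(-c2cc(-c3ccccc3F)cc(-c3ccccc3O)n2)cc1`: in a functional assay on HeLa cells (Homo sapiens) for inhibition (on this read-out higher numbers stand for weaker inhibition and lower numbers for stronger inhibition), compound 1 gives > 50000 nM, a limit of the assay.
Compound 2 `Oc1ccc(-c2cc(-c3cccc(F)c3)cc(-c3ccccc3O)n2)cc1`: in this assay compound 2 gives > 50000 nM, a limit of the assay.
Compound 3 `Oc1cccc(-c2cc(-c3ccc(C(F)(F)F)cc3)cc(-c3ccccc3O)n2)c1`: in this assay compound 3 gives > 50000 nM, a limit of the assay.

Compound 3 stands only as a limit in this assay. Among the compounds with values here, the two further values shown are limits as well, so no compound of the set gives a number. Compound 4 `Oc1ccc(-c2cc(-c3ccc(C(F)(F)F)cc3)cc(-c3ccccc3O)n2)cc1` is not yet measured in this assay. It differs from compound 3 in one place: 4-hydroxyphenyl in place of 3-hydroxyphenyl on an aromatic carbon.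

One measured step is recorded, a step that the two limits leave unreadable from compound 1 to compound 2. It concerns a fluorophenyl group and not the hydroxyphenyl group that moves here, and its size is not readable. All values sit at the limit of > 50000 nM in this assay, at which 3 of the 3 values shown sit. Within the data shown here, no step in the set therefore says anything readable about the change from compound 3 to compound 4, and no value in the set is a number.

Compound 4 is expected to remain at the limit as well. The estimated step that the limit leaves unreadable from compound 3 to compound 4 is expected to be none that can be read beyond the scatter. Compound 4 is estimated at 70000 nM, with a range from 25000 nM to 200000 nM.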

Compound 4, half-maximal inhibitory concentration: > 50000 nM
Compound 4: a limit, no number (the forecaster's own chance of this, stated with the estimate: 85%); the middle value is on the limit's open side.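

The steps from compound 1, compound 2 and compound 3 to compound 4 cannot be read in this assay, since all four compounds give a limit of the assay and no number: the limit of > 50000 nM in this assay, at which 4 of the 4 values shown sit.

The compounds shown leave open at what concentration any of them inhibits, and whether moving the hydroxyphenyl group changes inhibition at all.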